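The source may report more compounds than this note shows. Statements on the series, on what has been measured and on what is new or still open speak of the compounds shown alone.

Compound 1 `C[C@@H]1CN(c2cc(C(F)(F)F)nn2-c2ccc(S(C)(=O)=O)cn2)[C@H](C)CO1`: 100 ug/mL
Compound 2 `CS(=O)(=O)c1ccc(-n2nc(C(F)(F)F)cc2NC2CCCC2)nc1`: 25 ug/mL
Compound 3 `CS(=O)(=O)c1ccc(-n2nc(C(F)(F)F)c(C#N)c2NC2CCCC2)nc1`: "not determined" (no result reported)

In a physicochemical assay for solubility (on this read-out lower numbers stand for lower solubility and higher numbers for higher solubility), only two of these compounds carry a number. Compound 2 stands lower at 25 ug/mL, beneath compound 1 at 100 ug/mL, while compound 3 offers no result to compare.

The next compound to be measured is compound 4 `CC(C)(C)COc1cc(C(F)(F)F)nn1-c1ccc(S(C)(=O)=O)cn1`. It departs from compound 2 at a single place: neopentyloxy in place of cyclopentylamino on an aromatic carbon. The exchange removes the five-membered ring and the hydrogen-bond donor, and the new group is a chain attached through oxygen.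

Among the measured compounds shown here, only one measured step bears on this, a 4.0-fold lower number from compound 1 to compound 2 (0.60 log units; beyond the scatter). It was modest but beyond the scatter. The group exchanged in it sits on an aromatic carbon. That step does not contain the exchange made here, so it serves only as a rough guide to how far this assay can move when a group at this kind of place is replaced. The data hold no direct comparison of an oxygen-linked chain with an amino group. A change smaller than that step is therefore expected, with a slight lean towards a lower number. The expected change is a 1.7-fold lower number from compound 2 to compound 4 (0.22 log units; within the scatter). Compound 4 is estimated at 15 ug/mL, with an expected range from 4 ug/mL to 60 ug/mL.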

Compound 4, solubility: 100 ug/mL
The estimate for compound 4 lay 6.7-fold (0.82 log units) below the measured number, and the stated range ends below it.
By their numbers in this assay, from the lowest: compound 2; then compounds 1 and 4 (each within the scatter of the next).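

In this assay, replacing cyclopentylamino with neopentyloxy on this aromatic carbon, next to the ring nitrogen, gave a 4.0-fold higher number from compound 2 to compound 4 (0.60 log units; beyond the scatter), a step between two groups of 6 heavy atoms each, so that group size as counted by heavy atoms did not have to change for the number to move beyond the scatter. Among the compounds shown here, the open-chain neopentyloxy group and the ring-bearing group of compound 1 show no change at the digits printed from compound 1 to compound 4 (within the scatter), which leaves compound 2 as the one compound of the three with a number that stands apart from the others. Nothing measured here offers an explanation for either step.

The compounds shown leave open whether the step follows the oxygen link in place of the nitrogen link or the open chain in place of the five-membered ring, and a cyclopentyloxy group or a neopentylamino group at this place would separate the two. They also leave open whether a shorter chain such as ethoxy would stay level with compound 4 in this assay, and how the nitrile of compound 3 would read against compound 2.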